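Methylation of a phenol across two flavone cores

A few compounds are considered here, and "the series" means these few. Any claim that something is new, unique, unknown or untested is made for them only; others in the source may bear on it.

Compound 1 `COC(=O)c1c(-c2ccc(OC)cc2)oc2ccccc2c1=O`, compound 2 `COC(=O)c1c(-c2ccc(O)cc2)oc2ccccc2c1=O` and compound 3 `COc1cc(-c2cc(=O)c3ccc(O)cc3o2)cc(OC)c1OC` have been tested in a functional assay on A549 cells (Homo sapiens) for cytotoxicity, read by MTT assay, with a stated time of 6 days; a higher number here means that more compound is needed for the effect, a lower number that less compound is needed. Compound 1 reaches only the limit > 25 ug/mL, not a number. Compound 2 likewise gives only the limit > 25 ug/mL. Compound 3 also stops at the limit > 25 ug/mL. Compound 2 and compound 1 differ by methyl in place of hydrogen on an oxygen on an aromatic ring; the step that the two limits leave unreadable from compound 2 to compound 1 cannot be read, since both ends sit at the limit of > 25 ug/mL in this assay, at which 3 of the 3 values shown sit. The difference between the cores of compound 3 and compound 2 is not broken down here. Compound 4 `COc1ccc2c(=O)cc(-c3cc(OC)c(OC)c(OC)c3)oc2c1` is not yet measured; it differs from compound 3 by methyl in place of hydrogen on an oxygen on an aromatic ring, the same change as from compound 2 to compound 1. Given that every value so far rests at the limit of > 25 ug/mL in this assay, at which 3 of the 3 values shown sit, the step that the limit leaves unreadable from compound 3 to compound 4 is expected to be small, and compound 4 is estimated at 30 ug/mL in this assay, most likely reported again as a limit.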

Compound 4, concentration for half-maximal effect: > 25 ug/mL
Compound 4: only a limit was reported (the forecaster's own chance of this, stated with the estimate: 75%); the middle value does not contradict the limit.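

The step between compound 3 and compound 4 cannot be read, since both compounds stop at a limit: the limit of > 25 ug/mL in this assay, at which 4 of the 4 values shown sit. The compounds shown leave open whether methylating this phenol changes cytotoxicity on either core in this assay, since no compound gives a number.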